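Swapping nitro for bromo on compound 3

The compounds below may be only part of what the source reports. "The series", "measured", "known", "first", "only" and "open" are said of these compounds alone.

Compound 1 `c1ccc(/N=N/N2CCN(c3ccccc3)CC2)cc1` gives >= 100000 nM (a limit of the assay)
Compound 2 `c1ccc(/N=N/c2ccc(NC[C@@H]3CCCN4CCCC[C@H]34)c3c2CCCC3)cc1` gives 80000 nM
Compound 3 `O=[N+]([O-])c1ccc(/N=N/N2CCCC2)cc1` gives 90000 nM

In an ADME assay on Vero cells (Chlorocebus sabaeus) for cytotoxicity, read by crystal violet staining (on this read-out lower numbers stand for higher toxicity in this test and higher numbers for lower toxicity in this test), compound 3 reads 90000 nM and compound 2 reads 80000 nM and these two numbers lie within the scatter of each other. For compound 1 the result is only a limit of the assay (>= 100000 nM).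

Compound 4 `Brc1ccc(/N=N/N2CCCC2)cc1` differs from compound 3 in one place, with bromo in place of nitro on an aromatic carbon. Going by the values given here, no two measured compounds differ in one place, so this change has no direct precedent in the data. The expectation therefore rests on the numbers of compound 3 (90000 nM) and compound 2 (80000 nM). In this assay the expected change (a 1.3-fold lower number from compound 3 to compound 4 (0.11 log units; within the scatter)) stays within the scatter, with no firm direction. For compound 4 the estimated value is 70000 nM, with an expected range from 30000 nM to 100000 nM.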

Compound 4, half-maximal cytotoxic concentration: >= 100000 nM
Compound 4: a limit, no number; the forecaster's own chance of this, stated with the estimate: 30%; at least 1.4-fold (0.15 log units) between middle value and limit.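

In this assay compound 4 gives >= 100000 nM, which is a limit of the assay and not a number. Going by these compounds alone, the first one-place step in these data, bromo in place of nitro on an aromatic carbon, can therefore be read only as a floor: an at least 1.1-fold higher number from compound 3 to compound 4 (0.04 log units; that floor lies within the scatter); its real size remains unknown. Compound 4 shares this limit with compound 1 among the values shown: the limit of >= 100000 nM in this assay, at which 2 of the 4 values shown sit.

The compounds shown leave open how far compound 4 actually lies from compound 3, a gap that no limit can measure. They also leave open whether an amine or a carboxylic acid on the same aromatic carbon would give a number clearly lower than the limit, or would give the limit again.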